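Silyl ether size and cytotoxicity in a diterpenoid series

The source may hold more compounds than are shown below. What is called first, only, known or untested is meant among the compounds shown, and "the series" means these compounds.

Of the compounds shown here, three of a shared core have been tested in a functional assay on Lu1 cells (Homo sapiens) for cytotoxicity, read by sulforhodamine B assay; a lower number here means that less compound is needed, a higher number that more compound is needed for the effect. Compound 2 `C=C1CC[C@@H]2[C@](C)(CO[Si](C)(C)C(C)(C)C)[C@H](OC(C)=O)CC[C@@]2(C)[C@@H]1C/C=C1/C(=O)OC[C@H]1OC(C)=O` gives 2.92 uM. Compound 1 `C=C1CC[C@@H]2[C@](C)(CO[Si](C(C)C)(C(C)C)C(C)C)[C@H](OC(C)=O)CC[C@@]2(C)[C@@H]1C/C=C1/C(=O)OC[C@H]1OC(C)=O` gives 18.8 uM. Compound 3 `C=C1CC[C@@H]2[C@](C)(CO[Si](C)(C)C(C)(C)C)[C@H](O)CC[C@@]2(C)[C@@H]1C/C=C1/C(=O)OC[C@H]1O` gives 48.8 uM, the highest of the three numbers, with compound 1 nearest and compound 2 furthest from it. The difference between the cores of compound 2 and compound 3 is not broken down here.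

The change from compound 2 to compound 1 is a group of 10 heavy atoms (9 carbon, 1 silicon; no ring) in place of a group of 7 heavy atoms (6 carbon, 1 silicon; no ring), on an oxygen on a saturated carbon and made a step of a 6.4-fold higher number from compound 2 to compound 1 (0.81 log units; beyond the scatter) in this assay.

Compound 4 `C=C1CC[C@@H]2[C@](C)(CO[Si](C(C)C)(C(C)C)C(C)C)[C@H](O)CC[C@@]2(C)[C@@H]1C/C=C1/C(=O)OC[C@H]1O` has not been measured. It differs from compound 3 by a group of 10 heavy atoms (9 carbon, 1 silicon; no ring) in place of a group of 7 heavy atoms (6 carbon, 1 silicon; no ring), on an oxygen on a saturated carbon which is the same change as that from compound 2 to compound 1, at the same place. Within the data shown here, on that basis a step of about a 4.1-fold higher number from compound 3 to compound 4 (0.61 log units; beyond the scatter) is expected from compound 3 to compound 4, resting on the single measured pair, compound 2 to compound 1, with a 6.4-fold higher number from compound 2 to compound 1 (0.81 log units; beyond the scatter). Compound 4 is therefore estimated at 200 uM in this assay, within 60 uM to 600 uM.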

Compound 4, concentration for half-maximal effect: 3.01 uM
Estimate against measurement, compound 4: 66-fold (1.82 log units) above; measured number outside the range, below it.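

On the core of compound 3, the change gives a 16-fold lower number from compound 3 to compound 4 (1.21 log units; beyond the scatter), which runs opposite to the step measured on the core of compound 2. In this assay, the swap from the group of 7 heavy atoms to the group of 10 heavy atoms therefore has no single direction or size across these two cores: the same change on two cores in this assay, a 6.4-fold higher number (0.81 log units; beyond the scatter) from compound 2 to compound 1 and a 16-fold lower number (1.21 log units; beyond the scatter) from compound 3 to compound 4, 100-fold (2.02 log units) apart, beyond the scatter of two such steps

This shows that the step cannot be carried from one core to the other in this series, but two pairs give no general rule, and they do not show which part of the difference between the cores goes with the reversal.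

Still open, from the compounds shown here alone, is how a triethylsilyl group, a benzyl group or a free hydroxyl on the same oxygen would read on each core. Also open, going by these compounds, is whether a core carrying only one of the two acetate groups would follow the step on the core of compound 2 or the step on the core of compound 3.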